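The source may hold more compounds than are shown below. What is called first, only, known or untested is meant among the compounds shown, and "the series" means these compounds.

In a functional assay on the whole organism for inhibition, with Rattus norvegicus as the target, read by paw edema, with a stated time of 30 min, at a dose of 20 mg/kg by the oral route (a lower number here means a weaker effect, a higher number a stronger effect of the compound at the dose given), three compounds have been measured:

compound 1 `Clc1ccc(OCC2=NCCO2)cc1`: 30.3%
compound 2 `Brc1ccccc1OCC1=NCCO1`: 20.1%
compound 3 `Clc1ccccc1OCC1=NCCO1`: 13.7%

Compound 1 has the highest of these numbers. Compound 4 `Brc1ccc(OCC2=NCCO2)cc1` has not yet been measured; it differs from compound 1 by bromo in place of chloro on an aromatic carbon. The same kind of change has already been made once, from compound 3 to compound 2: bromo in place of chloro on an aromatic carbon. That step gave a number 6.4 percentage points higher from compound 3 to compound 2 (within the scatter). The two places are not identical: in compound 1 the change sits para to a group of 7 heavy atoms, in compound 3 ortho to it, so it is the same kind of change, not the same one. How the core of compound 1 differs from that of compound 3 is not broken down here. Resting on the small step from compound 3 to compound 2, the expected step is a number 4.7 percentage points higher from compound 1 to compound 4 (within the scatter). Compound 4 is estimated at 35%, between 22% and 48%.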

Compound 4, a percentage reported as inhibition, in the whole organism at one dose (the size of the read-out at that dose, not a potency): 35.5%
For compound 4 the middle estimate is 0.5 percentage points below the measured one; the range from low to high includes it.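

Putting bromo in place of chloro on an aromatic carbon gave a number 5.2 percentage points higher from compound 1 to compound 4 (within the scatter) in this assay. Set beside the earlier case, the change carries over between these two cores with no visible difference: the same change on two cores in this assay, a number 6.4 percentage points higher (within the scatter) from compound 3 to compound 2 and a number 5.2 percentage points higher (within the scatter) from compound 1 to compound 4, 1.2 percentage points apart, within the scatter of two such steps. Each step on its own lies within the usual scatter, so this does not show that bromo and chloro truly differ here, and two cores cannot speak for the whole series.

The compounds shown leave open what other groups on the same aromatic carbon would do, such as a methoxy group, a nitrile or an amine. Also open, as far as these compounds go, is whether the two steps would stay alike at another dose or time.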